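This account rests on a few compounds, and the source may have more. Where it says the series, first, only, none or still open, it means among the compounds named here.

Measured so far:
compound 1 `COc1ccc(C2=NN(C(N)=S)CC2)cc1` — 15500 nM
compound 2 `CNC(=S)N1CC(C)C(c2ccc(OC)cc2)=N1` — 49400 nM

In an in vitro assay on cells for inhibition of Amine oxidase [flavin-containing] B (Homo sapiens), read by Amplex Red, with a stated time of 15 min (a higher number here means a weaker inhibitor, a lower number a stronger inhibitor), compound 2 gives the highest of the two numbers; compound 1 gives the lower one, and the gap between them is beyond the scatter. Compound 3 `COc1ccc(C2=NN(C(N)=S)CC2C)cc1` is not yet measured. It differs from compound 2 by hydrogen in place of methyl on an amide-type nitrogen; cut one bond further out, methylamino to amino. Within the data shown here, no measured pair isolates this change. Compound 1 carries the amino form of the thiourea, and because its value 15500 nM lies under that of compound 2, a downward step beyond the scatter is expected. For compound 3 the expected step in this assay is a 2.5-fold lower number from compound 2 to compound 3 (0.39 log units; beyond the scatter), giving an estimate of 20000 nM within 8000 nM to 60000 nM.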

Compound 3, half-maximal inhibitory concentration: 84600 nM
Estimate against measurement, compound 3: 4.2-fold (0.63 log units) below, and the stated range ends below it.
By their numbers in this assay, from the lowest: compound 1; then compounds 2 and 3 (each within the scatter of the next).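

In this assay, hydrogen in place of methyl on the amide-type nitrogen gives a 1.7-fold higher number from compound 2 to compound 3 (0.23 log units; within the scatter), so this change has no readable effect in this pair. Methyl in place of hydrogen on a saturated ring carbon gives a 5.5-fold higher number from compound 1 to compound 3 (0.74 log units; beyond the scatter), making that carbon the position with a step beyond the scatter. No measured finding accounts for either step.

Still open, on these data alone, is whether an ethyl or hydroxyl group on that saturated ring carbon would give a similar step. Also open, as far as these compounds go, is whether a longer chain on the amide-type nitrogen would remain within the scatter.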